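Adding a hydroxy group to compound 2

The compounds below may be only part of what the source reports. "The series", "measured", "known", "first", "only" and "open" are said of these compounds alone.

Compound 1 `COc1ccc(C2CC(Nc3nc4ccc(C)cc4s3)=NN2C(C)=O)cc1` gives 37.3 umol/kg
Compound 2 `COc1ccc(C2CC(Nc3nc4ccc([N+](=O)[O-])cc4s3)=NN2C(C)=O)cc1` gives 145 umol/kg

In a functional assay on the whole organism (Hindlimb, strain albino) with Mus musculus as the target, in the maximal electroshock model, with a stated time of 0.5 h (on this read-out higher numbers stand for an effect only at larger amounts of compound and lower numbers for an effect already at smaller amounts), compound 2 has the higher of the two numbers, so it needs the larger amount. Compound 3 `COc1ccc(C2CC(Nc3nc4ccc([N+](=O)[O-])cc4s3)=NN2C(C)=O)cc1O` differs from compound 2 by hydroxy in place of hydrogen on an aromatic carbon. Among the measured compounds shown here, the only measured step (a 3.9-fold higher number from compound 1 to compound 2 (0.59 log units; beyond the scatter)) is nitro in place of methyl on an aromatic carbon. It is a modest step but a different change, so it gives no direction here. No shift beyond the usual scatter is therefore expected. The estimated step (a 1.0-fold higher number from compound 2 to compound 3 (0.01 log units; within the scatter)) is close to none. For compound 3 the expected value is 150 umol/kg (range 60 umol/kg to 360 umol/kg).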

Compound 3, dose for half-maximal effect: 178 umol/kg
Beside the measured number, compound 3's estimate is 1.2-fold (0.07 log units) below it, and the stated range covers the measured number.
By their numbers in this assay, from the lowest: compound 1; then compounds 2 and 3 (each within the scatter of the next).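

In this assay, hydroxy in place of hydrogen on the aromatic carbon ortho to the methoxy group gives a 1.2-fold higher number from compound 2 to compound 3 (0.09 log units; within the scatter) and so compound 2 and compound 3 cannot be told apart on this read-out. Among the compounds shown here, this is the first measured step at this ring position, since the earlier step concerned a different place and a different group. No measured evidence bears on this result. On these data alone, whether an amine or a carboxylic acid at this position would behave the same stays open. So does whether hydroxy would give a similar result on compound 1, which has methyl in place of nitro.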